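The source may report more compounds than this note shows. Statements on the series, on what has been measured and on what is new or still open speak of the compounds shown alone.

Working notes on the series, read in an ADME assay on HEK-293T cells (Homo sapiens) for cytotoxicity, read by CCK-8 assay, with a stated time of 48 h; a higher number here means a weaker inhibitor, a lower number a stronger inhibitor. Compound 1 `Nc1ccc(Oc2ccccc2-c2ccc(S(=O)(=O)NCCNC(=O)Nc3ccc(Cl)cc3)s2)cc1` reads > 20000 nM, which is a limit and not a number. Compound 2 `O=C(NCCNS(=O)(=O)c1ccc(-c2ccccc2O[C@H]2CC[C@@H](O)CC2)s1)Nc1ccc([N+](=O)[O-])cc1` gives 8600 nM, and compound 3 `O=[N+]([O-])c1ccc(NC(=S)NCCNS(=O)(=O)c2ccc(-c3ccccc3O[C@H]3CC[C@@H](O)CC3)s2)cc1` gives 20000 nM. Compound 3 therefore holds the higher of the two exact numbers, and the swap on an amine nitrogen accounts for a 2.3-fold higher number from compound 2 to compound 3 (0.37 log units; beyond the scatter).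

Compound 4 `O=[N+]([O-])c1ccc(NC(=S)NCCNS(=O)(=O)c2ccc(-c3ccccc3OCc3ccccc3)s2)cc1` has not yet been measured. Its difference from compound 3 is benzyl in place of 4-hydroxycyclohexyl on an oxygen on an aromatic ring.

Within the data shown here, no measured step isolates this change. Among the measured compounds shown here, the single step available, a 2.3-fold higher number from compound 2 to compound 3 (0.37 log units; beyond the scatter), lies at another place and gives only a rough scale for the series. Compound 1 also has an aromatic ring on that oxygen and stands at the limit of > 20000 nM in this assay, at which 1 of the 3 values shown sits, but it differs from compound 3 in more than one place, so it offers weak support at best.

With compound 3 at 20000 nM, the top of the exact numbers, a modest move towards a lower number in this assay is the more likely outcome, though the direction is not secure. The expected step is a 1.4-fold lower number from compound 3 to compound 4 (0.15 log units; within the scatter). For compound 4 the estimated value is 14000 nM, with an expected range of 5000 nM to 30000 nM.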

Compound 4, half-maximal inhibitory concentration: 8900 nM
The estimate for compound 4 lay 1.6-fold (0.20 log units) above the measured number; low and high end bracket the measured number.
By their numbers in this assay, from the lowest: compounds 2 and 4 (each within the scatter of the next); then compound 3.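

Swapping 4-hydroxycyclohexyl for benzyl on an oxygen on an aromatic ring gives, in this assay, a 2.2-fold lower number from compound 3 to compound 4 (0.35 log units; beyond the scatter), so this position affects the reading, which the earlier compounds could not show because none of their measured steps lay here. Among these compounds, the only earlier step, a 2.3-fold higher number from compound 2 to compound 3 (0.37 log units; beyond the scatter), sits on an amine nitrogen, so the series now has one modest step at each of two places, and they run in opposite directions on the scale of this assay. The change also removes the hydroxyl and the two defined stereocentres of 4-hydroxycyclohexyl while leaving the count of heavy atoms unchanged, and no measurement shown bears on why the number falls.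

Still open, from the compounds shown here alone, is whether the lower number follows from the aromatic ring of benzyl or from the loss of the hydroxyl; a plain cyclohexyl on that oxygen would separate the two. Compound 1 also carries an aromatic ring on that oxygen, but its reading is a limit and gives no step at this place: the limit of > 20000 nM in this assay, at which 1 of the 4 values shown sits.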